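The compounds below may be only part of what the source reports. "The series", "measured", "known", "first", "only" and "open" are said of these compounds alone.

In a functional assay on NCI-H661 cells (Homo sapiens) for cytotoxicity, read by WST assay, with a stated time of 72 h (on this read-out higher numbers stand for weaker inhibition and lower numbers for stronger inhibition), compound 1, with the structure `CCN(CC)CCCOc1cc2ncnc(Nc3nc4ccc(C(=O)Nc5c(C)cccc5Cl)cc4s3)c2cc1OC`, gives 11200 nM. Compound 2, with the structure `COc1cc2c(Nc3nc4ccc(C(=O)Nc5c(C)cccc5C)cc4s3)ncnc2cc1OCCCN1CCCCC1`, reaches only a limit of the assay: in this assay compound 2 gives > 100000 nM, and the limit of > 100000 nM in this assay, at which 1 of the 2 values shown sits, marks where it stands. Compound 3, with the structure `COc1cc2c(Nc3nc4ccc(C(=O)Nc5c(C)cccc5Cl)cc4s3)ncnc2cc1OCCCN1CCCCC1`, differs from compound 2 by chloro in place of methyl on an aromatic carbon. Since compound 2 has only a limit, the size of the step in this assay cannot be read from measured numbers; compound 3 is expected to gain potency by an at least 3.3-fold lower number from compound 2 to compound 3 (0.52 log units; beyond the scatter). For compound 3 the expected value is 30000 nM, ranging from 8000 nM to 100000 nM.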

Compound 3, half-maximal inhibitory concentration: 13800 nM
Beside the measured number, compound 3's estimate is 2.2-fold (0.34 log units) above it; the range from low to high includes it.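

In this assay, chloro in place of one methyl of the 2,6-dimethylphenyl group gives an at least 7.2-fold lower number from compound 2 to compound 3 (0.86 log units; beyond the scatter), so this place on the ring responds to the change. Compound 2 has only a limit, so the full size of this step cannot be read: the limit of > 100000 nM in this assay, at which 1 of the 3 values shown sits. With the 2-chloro-6-methylphenyl group held fixed, the chain end gives a 1.2-fold higher number from compound 1 to compound 3 (0.09 log units; within the scatter), which lies within the scatter.

Still open, on these data alone, is how a fluoro or methoxy group would fare at this place on the ring, and whether a morpholin-4-yl chain end would match piperidin-1-yl.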